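This account rests on a few compounds, and the source may have more. Where it says the series, first, only, none or still open, it means among the compounds named here.

Measured so far:
- compound 1 `O=C(O)/C=C/c1ccncc1-c1ccc2cc[nH]c2c1`: 2.4 nM
- compound 2 `CNC(=O)CCc1ccncc1-c1ccc2ccccc2c1`: 21.1 nM
- compound 3 `NC(=O)/C=C/c1ccncc1Br`: 2420 nM

All three were tested in an assay on a protein complex for inhibition of CDK8/Cyclin C (Homo sapiens), with a stated time of 1 h; a lower number here means a stronger inhibitor, a higher number a weaker inhibitor. Among them compound 2 stands second highest: compound 1 gives a lower number, and the gap between the two lies beyond the usual scatter, while compound 3 gives a far higher number, also beyond the scatter. Compound 4 `O=C(O)/C=C/c1ccncc1-c1ccc2ccccc2c1` has not yet been measured. It differs from compound 2 in one place: 2-carboxyethenyl in place of 2-(methylcarbamoyl)ethyl on an aromatic carbon. The rest of the molecule, including the large group on the shared core, is unchanged.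

Among the compounds with values here, no step between two measured compounds isolates this change, so its effect can only be inferred indirectly. Compound 1 carries the same 2-carboxyethenyl group that enters here, and in this assay compound 1 gives 2.4 nM, a clearly lower number than compound 2. On that basis the change is expected to move the number downward by more than the scatter, towards stronger inhibition. For compound 4 in this assay the estimated value is 4 nM, with a likely range from 1.5 nM to 12 nM. This estimate means an expected step of a 5.3-fold lower number from compound 2 to compound 4 (0.72 log units; beyond the scatter).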

Compound 4, half-maximal inhibitory concentration: 5 nM
Estimate against measurement, compound 4: 1.3-fold (0.10 log units) below, and the stated range covers the measured number.
By their numbers in this assay, from the lowest: compound 1; then compound 4; then compound 2; then compound 3.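

Within the data shown here, measured in this assay, the swap of 2-(methylcarbamoyl)ethyl for 2-carboxyethenyl gives a 4.2-fold lower number from compound 2 to compound 4 (0.63 log units; beyond the scatter) and offers the first direct reading of this change with the rest of the molecule held fixed. It shows that the group on this aromatic carbon, ortho to a large group and opposite the ring nitrogen, can shift the number beyond the usual scatter, with the lower number here belonging to the chain that ends in a carboxylic acid. This single swap alters two things at once, since the chain end changes from a methyl amide to a carboxylic acid and the chain also gains a double bond, and no measurement shown here explains the step.

The compounds shown leave open which of those two alterations accounts for the step; a 2-carboxyethyl group, with the acid on a saturated chain, or a 2-(methylcarbamoyl)ethenyl group, with the methyl amide on the unsaturated chain, would pull them apart. As far as these compounds go, how an amine or a longer chain at this position would read also remains unknown.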